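Swapping Nitro for Amino Across Two Amide Cores

The compounds below may be only part of what the source reports. "The series", "measured", "known", "first", "only" and "open" are said of these compounds alone.

Compound 1, `COc1ccc(NC(=O)c2cc(OC)c(OC)c(OC)c2)cc1[N+](=O)[O-]`: 17600 nM
Compound 2, `COc1ccc(NC(=O)c2cc(OC)c(OC)c(OC)c2)cc1N`: 6500 nM
Compound 3, `COc1ccc(C(=O)Nc2cc(OC)c(OC)c(OC)c2)cc1[N+](=O)[O-]`: 2000 nM

All three numbers come from a functional assay on HCT-15 cells (Homo sapiens) for antiproliferative activity, read by MTT assay, with a stated time of 72 h; a higher number here means a weaker inhibitor, a lower number a stronger inhibitor. Compound 1 and compound 2 share one core and differ in a single place: amino in place of nitro on an aromatic carbon That change produced a 2.7-fold lower number from compound 1 to compound 2 (0.43 log units; beyond the scatter), a gain that is modest but real.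

Compound 3 is built from the same atoms as compound 1, joined differently; the difference between the two cores is not broken down here. Among the three measured compounds, compound 3 stands lowest in this assay, and both of its gaps to the others lie beyond the scatter.

Compound 4, `COc1ccc(C(=O)Nc2cc(OC)c(OC)c(OC)c2)cc1N`, has not yet been measured. It differs from compound 3 by one change: amino in place of nitro on an aromatic carbon The surroundings of that place are described in the same words as for the first pair, so this is the same change, now made on the core of compound 3.

Among the compounds with values here, for compound 4 a step of about a 2.5-fold lower number from compound 3 to compound 4 (0.40 log units; beyond the scatter) is expected, because a 2.7-fold lower number from compound 1 to compound 2 (0.43 log units; beyond the scatter) is the only guide to this change. Compound 4 is estimated at 800 nM. For compound 4 the expected range runs from 250 nM to 2500 nM, allowing for the untested core.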

Compound 4, half-maximal inhibitory concentration: > 100000 nM
Compound 4: no number, only a limit; the forecaster's own chance of this, stated with the estimate: 2%; middle value at least 120-fold (2.09 log units) away from the limit.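

In this assay compound 4 gives > 100000 nM, which is a limit of the assay and not a number. Putting amino in place of nitro gave an at least 50-fold higher number from compound 3 to compound 4 (1.69 log units; beyond the scatter), so a change that brought a modest gain on the core of compound 1 brought a large loss on the core of compound 3, and the two results clearly disagree: the same change on two cores in this assay, a 2.7-fold lower number (0.43 log units; beyond the scatter) from compound 1 to compound 2 and an at least 50-fold higher number (1.69 log units; beyond the scatter) from compound 3 to compound 4, at least 130-fold (2.13 log units) apart, beyond the scatter of two such steps This shows that, for these two pairs, the result of this change on one core did not predict its result on the other, but it does not explain the reversal, set a rule for the wider series, or give the full size of the loss: the limit of > 100000 nM in this assay, at which 1 of the 4 values shown sits.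

On these data alone, it remains open which feature of the two cores governs the outcome, and whether the reversal would recur on a third core. As far as these compounds go, it is also open how compound 3 would respond to other groups at the same place, such as a nitrile, a carboxylic acid or an acetamide.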